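This account rests on a few compounds, and the source may have more. Where it says the series, first, only, none or still open, it means among the compounds named here.

Working notes on the series. Compound 1 `O=C1CC(c2ccccc2OCc2ccc(F)cc2)Oc2ccccc21` is the reference point: in a functional assay on the whole organism (strain Sprague-Dawley) for inhibition, with Rattus norvegicus as the target, read by ELISA, with stated times of 12 h, 6 h and 2 h, at a dose of 150 umol/kg by the oral route (a lower number here means less inhibition, a higher number more inhibition at the dose given (going by the name of the read-out)), compound 1 gives 43.6%. Compound 2 `CC(C)c1ccc(COc2ccccc2C2CC(=O)c3ccccc3O2)cc1` carries isopropyl in place of fluoro on an aromatic carbon, and in this assay compound 2 gives 24.6%. The step between them is a number 19 percentage points lower from compound 1 to compound 2 (beyond the scatter). Among the compounds with values here, on the two numbers so far compound 2 stands lowest; its only neighbour is compound 1, which sits higher by that same step.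

Compound 3 `O=C1CC(c2ccccc2OCc2ccccc2)Oc2ccccc21` is still to be measured. It differs from compound 2 in one place: hydrogen in place of isopropyl on an aromatic carbon. Within the data shown here, the only measured step that touches this aromatic carbon is the exchange of fluoro for isopropyl, a modest loss in this assay; nothing yet shows what a bare hydrogen does there. Compound 1, which also lacks the isopropyl, gives 43.6%, so some recovery towards that value is expected, though without a direct precedent the call is uncertain. The expected step is a number 10.4 percentage points higher from compound 2 to compound 3 (beyond the scatter). Compound 3 is estimated at 35% in this assay, with a range of 15% to 55%.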

Compound 3, a percentage reported as inhibition, in the whole organism at one dose (the size of the read-out at that dose, not a potency): 28.4%
Compound 3: middle estimate off by 6.6 percentage points, on the high side; measured number inside the range.
By their numbers in this assay, from the lowest: compounds 2 and 3 (each within the scatter of the next); then compound 1.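

In this assay there is a number 3.8 percentage points higher from compound 2 to compound 3 (within the scatter) and so the change from 4-isopropylphenyl to phenyl gives no readable difference at this aromatic carbon. Against fluoro, hydrogen gives a number 15.2 percentage points lower from compound 1 to compound 3 (beyond the scatter) and this places hydrogen with isopropyl, so the earlier loss seen with isopropyl is not specific to that group: among these three compounds, fluoro alone stands apart from the other two groups. No independent measurement on these compounds bears on the reason for this difference.

From the compounds shown here alone, whether the higher number belongs to fluoro in particular or would also appear with chloro, methoxy, an amine or a carboxylic acid on this same carbon remains open. Also open, going by these compounds, is whether the hydrogen and isopropyl compounds would stay together with a longer chain in place of isopropyl, and whether the standing of fluoro would hold with any change elsewhere on the shared core.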